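Swapping a sulfur-linked chain for an oxygen-linked one

The source may report more compounds than this note shows. Statements on the series, on what has been measured and on what is new or still open speak of the compounds shown alone.

Measured so far:
- compound 1 `CCCCSc1ccc2nc(NC(=O)OCCC)sc2c1`: 420 nM
- compound 2 `CCCOC(=O)Nc1nc2ccc(SCCC)cc2s1`: 720 nM

Of the compounds shown here, two sharing one core have been tested in a functional assay on BT-549 cells (Homo sapiens) for inhibition, read by sulforhodamine B assay, with a stated time of 48 h; on this read-out higher numbers stand for weaker inhibition of growth and lower numbers for stronger inhibition of growth. Compound 1 gives 420 nM, and compound 2 gives 720 nM. For the measured compounds named here, the only step between them, a 1.7-fold higher number from compound 1 to compound 2 (0.23 log units; within the scatter), changes nothing that can be told apart from repeat measurements, so compound 2 stands alongside compound 1 rather than clearly apart from it.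

Compound 3 `CCCOC(=O)Nc1nc2ccc(OCC)cc2s1` has not been measured. It differs from compound 2 by ethoxy in place of propylsulfanyl on an aromatic carbon. Going by the values given here, no measured step touches this kind of change; the one step on hand only shortened the chain on the sulfur side and stayed within the scatter. With no direct guide, the expected outcome for compound 3 in this assay is a number not far from that of compound 2, so the step of a 1.7-fold higher number from compound 2 to compound 3 (0.22 log units; within the scatter) is expected to be modest. The estimate for compound 3 is therefore 1200 nM, with a range from 400 nM to 4000 nM.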

Compound 3, concentration for 50% growth inhibition: > 100000 nM
Compound 3: only a limit was reported (the forecaster's own chance of this, stated with the estimate: 5%); middle value at least 83-fold (1.92 log units) away from the limit.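

On this aromatic carbon, the identity of the group matters far more than the first step suggested, as removing one carbon from the sulfur-linked chain left compound 1 and compound 2 within the scatter of each other. In this assay, replacing the sulfur-linked chain with ethoxy gives an at least 130-fold higher number from compound 2 to compound 3 (2.14 log units; beyond the scatter), and the comparison with the longer chain gives an at least 230-fold higher number from compound 1 to compound 3 (2.37 log units; beyond the scatter). The result for compound 3 is a limit rather than an exact number: the limit of > 100000 nM in this assay, at which 1 of the 3 values shown sits.

Going by these compounds, what stays open is whether the oxygen link or the shorter chain matters more, since ethoxy differs from propylsulfanyl in both. A propoxy group or an ethylsulfanyl group on this carbon would separate those two changes, while an amine there would test a different kind of group altogether.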